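Aryl to benzyl on the amine of the shared core

The compounds below may be only part of what the source reports. "The series", "measured", "known", "first", "only" and "open" are said of these compounds alone.

Measured so far:
compound 1 `COc1cccc(Nc2n[nH]c(-c3cccnc3Nc3cc(OC)cc(OC)c3)n2)c1` gives 72%
compound 2 `COc1cc(Nc2ncccc2-c2nc(Nc3ccc(OC)cc3OC)n[nH]2)cc(OC)c1` gives 17%
compound 3 `COc1cc(Nc2n[nH]c(-c3cccnc3Nc3cc(OC)cc(OC)c3)n2)cc(OC)c1` gives "not determined" (no result reported)

In a functional assay on A-431 cells (Homo sapiens), tested at 0.1 uM (on this read-out lower numbers stand for less inhibition and higher numbers for more inhibition at the one concentration tested (going by the name of the read-out)), compound 1 gives 72%, while compound 2 gives 17%. Within the data shown here, the one step measured between neighbours, a number 55 percentage points lower from compound 1 to compound 2 (beyond the scatter), shows that changing the group on the nitrogen attached to the shared core can move the read-out by a large amount. Going by these compounds, compound 3 gives "not determined" (no result reported) in this assay, so its own level is unknown.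

Compound 4 `COc1ccc(CNc2n[nH]c(-c3cccnc3Nc3cc(OC)cc(OC)c3)n2)cc1` differs from compound 3 by 4-methoxybenzyl in place of 3,5-dimethoxyphenyl on a nitrogen on an aromatic ring. Among the measured compounds shown here, no measured step covers this exchange of an aryl for a benzyl group on that nitrogen, so the expectation rests only on the general lesson of a number 55 percentage points lower from compound 1 to compound 2 (beyond the scatter): a change at this position can be large in either direction, and the uncertainty is wide. Compound 4 is expected to give an estimated 30% in this assay. The estimated range for compound 4 runs from 5% to 70%.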

Compound 4, a percentage reported as inhibition, at one concentration (the size of the read-out at that concentration, not a potency): 22%
Compound 4: the middle estimate sits 8 percentage points above what was measured; measured number inside the range.
By their numbers in this assay, from the lowest: compounds 2 and 4 (each within the scatter of the next); then compound 1.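

In this assay, putting 4-methoxybenzyl in place of 2,4-dimethoxyphenyl on this nitrogen gives a number 5 percentage points higher from compound 2 to compound 4 (within the scatter), so these two groups cannot be told apart here. Putting the same benzyl group in place of 3-methoxyphenyl gives a number 50 percentage points lower from compound 1 to compound 4 (beyond the scatter), which shows that this benzyl group does not keep the high read-out seen with the 3-methoxyphenyl group. Compound 3 has no reported number, so the exchange of its 3,5-dimethoxyphenyl group for 4-methoxybenzyl cannot be read directly.

Going by these compounds, it remains open whether an amine or a carboxylic acid on the benzyl ring, or a longer chain in place of the benzyl group, would bring the read-out back up. Nothing available here explains why these groups give such different read-outs.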